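Triazole aryl variation in the diaryl urea series

The compounds below may be only part of what the source reports. "The series", "measured", "known", "first", "only" and "open" are said of these compounds alone.

Measured so far in a functional assay on HepG2 cells (Homo sapiens) for inhibition, read by MTT assay, with a stated time of 72 h; on this read-out lower numbers stand for stronger inhibition and higher numbers for weaker inhibition:
- compound 1, `Cc1cccc(-n2cc(COc3cccc(NC(=O)Nc4ccc(Cl)c(C(F)(F)F)c4)c3)nn2)c1`: 7270 nM
- compound 2, `N#Cc1ccc(-n2cc(COc3cccc(NC(=O)Nc4ccc(Cl)c(C(F)(F)F)c4)c3)nn2)cc1`: 2980 nM
- compound 3, `O=C(Nc1cccc(OCc2cn(-c3ccc(F)cc3)nn2)c1)Nc1ccc(Cl)c(C(F)(F)F)c1`: 1350 nM
- compound 4, `O=C(Nc1cccc(OCc2cn(-c3ccccc3C(F)(F)F)nn2)c1)Nc1ccc(Cl)c(C(F)(F)F)c1`: not yet measured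

Compound 3 gives the lowest number of the three measured; compound 2 is nearest, at a 2.2-fold lower number from compound 2 to compound 3 (0.34 log units; beyond the scatter), and compound 1 is furthest, at a 5.4-fold lower number from compound 1 to compound 3 (0.73 log units; beyond the scatter). All three share the same core and differ only in the aryl group on the triazole nitrogen.

Compound 4 continues this variation: 2-(trifluoromethyl)phenyl in place of 4-fluorophenyl on an aromatic nitrogen. The measured steps that bear on it all touch the same aryl group. From compound 1 to compound 2 the number moved by a 2.4-fold lower number from compound 1 to compound 2 (0.39 log units; beyond the scatter); the step into compound 3 from compound 1 was a 5.4-fold lower number from compound 1 to compound 3 (0.73 log units; beyond the scatter) and from compound 2 was a 2.2-fold lower number from compound 2 to compound 3 (0.34 log units; beyond the scatter). Every aryl change so far has shifted the number modestly but beyond the scatter. For the measured compounds named here, no measured step, however, brings a trifluoromethyl onto this phenyl, nor places a group at the 2-position of it, so the direction for compound 4 is open. Since compound 3 already carries the lowest number, a small move toward higher numbers is the more likely outcome. For compound 4 the expected step is a 1.6-fold higher number from compound 3 to compound 4 (0.21 log units; within the scatter). Compound 4 is therefore estimated at 2200 nM, with a range of 700 nM to 6500 nM.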

Compound 4, half-maximal inhibitory concentration: 2320 nM
Estimate against measurement, compound 4: 1.1-fold (0.02 log units) below; the measured number falls inside the stated range.
By their numbers in this assay, from the lowest: compounds 3, 4 and 2 (each within the scatter of the next, the first and the last beyond it); then compound 1.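

In this assay, the aromatic nitrogen accepts 2-(trifluoromethyl)phenyl, with 10 heavy atoms against 7 in the 4-fluorophenyl it replaces, and the step stays inside the scatter: a 1.7-fold higher number from compound 3 to compound 4 (0.24 log units; within the scatter). The exchange for 4-cyanophenyl also stays inside the scatter, a 1.3-fold lower number from compound 2 to compound 4 (0.11 log units; within the scatter), whereas the exchange for 3-methylphenyl goes beyond it, a 3.1-fold lower number from compound 1 to compound 4 (0.50 log units; beyond the scatter), so compound 1 now lies beyond the scatter of all three other compounds, and a trifluoromethyl group on this phenyl, named here as 2-(trifluoromethyl)phenyl, sits among the lower numbers of the series. No measured property of these aryl groups is available to bear on these differences, so the numbers stand without an explanation.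

The aryl groups shown carry only methyl, nitrile, fluoro or trifluoromethyl, so it remains open how an amine or a carboxylic acid on this phenyl, or a longer chain in its place, would behave. The shared core is constant across all four compounds, which leaves open what a change there would do in this assay.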